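Replacing a Cyclopropyl Ketone with a Sec-Butyl Ketone

The source may report more compounds than this note shows. Statements on the series, on what has been measured and on what is new or still open speak of the compounds shown alone.

Compound 1 `O=C(c1cnn2c(C3CCNCC3)cc(=O)[nH]c12)C1CC1` is a potent inhibitor in a functional assay on a cell-free system (plasma, Homo sapiens), read by spectrophotometry, in the presence of a further agent that is not named here (a higher number here means a weaker inhibitor, a lower number a stronger inhibitor), where compound 1 gives 8 nM. Among the measured compounds shown here, that is the higher of the two numbers known here, yet compound 2 `CCCc1noc(-c2c(C)nn3c(C4CCNCC4)cc(=O)[nH]c23)n1`, which in this assay gives 6 nM, sits so close that the two cannot be told apart. Compound 3 `CCC(C)C(=O)c1cnn2c(C3CCNCC3)cc(=O)[nH]c12` is the same as compound 1 except for one change: sec-butyl in place of cyclopropyl on a carbonyl carbon. For the measured compounds named here, no two measured compounds differ in this way, so there is nothing to copy a step from. A small loss of potency, or none beyond the scatter, is expected, so that compound 3 is estimated at 12 nM (range 4 nM to 40 nM), a step of a 1.5-fold higher number from compound 1 to compound 3 (0.18 log units; within the scatter) that is expected to stay within the scatter.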

Compound 3, half-maximal inhibitory concentration: 8 nM
For compound 3 the middle estimate is 1.5-fold (0.18 log units) above the measured one; measured number inside the range.
By their numbers in this assay, from the lowest: compounds 2, 1 and 3 (each within the scatter of the next).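

In this assay, the three-membered ring of cyclopropyl on the carbonyl carbon proves unnecessary for potency: sec-butyl, which has no ring and one more carbon, takes its place with no change at the digits printed from compound 1 to compound 3 (within the scatter). This position therefore accepts at least one open, branched carbon group in place of the ring. Nothing available here gives a reason for this result. Still open, from the compounds shown here alone, is whether the same position would accept a longer chain such as n-hexyl, a phenyl ring, or a chain carrying an amine or a carboxylic acid.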